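The compounds below may be only part of what the source reports. "The series", "measured", "known", "first", "only" and "open" are said of these compounds alone.

Measured compounds:
compound 1 `Clc1ccc(N2C[C@@H]3C[C@H]2CN3)nn1` in an assay on brain for displacement of a labelled ligand from Neuronal acetylcholine receptor; alpha4/beta2 (Rattus norvegicus) (a lower number here means a stronger inhibitor, a higher number a weaker inhibitor), gives 6 nM;
compound 2 `CN1C[C@@H]2C[C@H]1CN2c1ccc(Cl)nn1` in this assay gives 139 nM;
compound 3 `Clc1ccc(N2C[C@H]3C[C@@H]2CN3)nn1` in this assay gives 0.2 nM.

Among these three, compound 1 holds the second highest number: a 23-fold higher number from compound 1 to compound 2 (1.36 log units; beyond the scatter), while a 30-fold lower number from compound 1 to compound 3 (1.48 log units; beyond the scatter), the latter resting on (the fact that compounds 1 and 3 differ only in the configuration as drawn).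

Compound 4 `c1ccc(-c2ccc(N3C[C@@H]4C[C@H]3CN4)nn2)cc1` differs from compound 1 by phenyl in place of chloro on an aromatic carbon. Neither measured step bears on this change: one concerns a methyl on an amine nitrogen in a ring, the other the configuration of the shared core, and both leave the chloro untouched. The direction of the step is therefore open; a moderate rise in the number is taken as the working guess, with wide uncertainty.

For compound 4 the estimate is 20 nM, within 3 nM to 150 nM, which would mean an expected 3.3-fold higher number from compound 1 to compound 4 (0.52 log units; beyond the scatter).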

Compound 4, inhibition constant: 31200 nM
The estimate for compound 4 lay 1600-fold (3.19 log units) below the measured number; the measured number lies above the stated range.
By their numbers in this assay, from the lowest: compound 3; then compound 1; then compound 2; then compound 4.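

Replacing chloro with phenyl on this aromatic carbon, next to the ring nitrogen, gives a 5200-fold higher number from compound 1 to compound 4 (3.72 log units; beyond the scatter) in this assay. The earlier compounds shown here showed only that the amine nitrogen and the configuration of the shared core affect the number; compound 4 shows that this position on the aromatic ring can affect it even more strongly. Nothing given here explains this step.

The compounds shown leave open how fluoro, methyl, methoxy or an amine would read at this position. They also leave open whether phenyl would cost as much on the mirror-image core of compound 3.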